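Demethylation of a macrocyclic amine: an oral exposure question

A few compounds are considered here, and "the series" means these few. Any claim that something is new, unique, unknown or untested is made for them only; others in the source may bear on it.

The three compounds here share one macrocyclic core. Compound 1 `C=C[C@@H]1C[C@]1(N[C@@H]1C[C@@H]2CN1C(=O)[C@H](C1CCCCC1)NCCCCCCCc1cc3c(cc(-c4ccccc4)nc3cc1OC)O2)C(=O)NS(=O)(=O)C1CC1` was examined in an ADME assay on the whole organism (plasma, strain Sprague-Dawley) for pharmacokinetics, with Rattus norvegicus as the target, with a stated time of 4 h, at a dose of 5 mg/kg by the oral route; on this read-out lower numbers stand for lower exposure and higher numbers for higher exposure at the dose given. Compound 1 reached only a limit of the assay in this assay, < 78.4 ng.h/mL. Compound 2 `C=C[C@@H]1C[C@]1(N[C@@H]1C[C@@H]2CN1C(=O)[C@H](C1CCCC1)NCCCCC/C=C/c1ccc3ccnc(c3c1)O2)C(=O)NS(=O)(=O)C1CC1` has no result in this assay; its entry reads "not determined" (no result reported). Compound 3 `C=C[C@@H]1C[C@]1(NC(=O)[C@@H]1C[C@@H]2CN1C(=O)[C@H](C1CCCCC1)N(C)[C@H](C)CCCCCCc1cccc3c1CN(C3)C(=O)O2)C(=O)NS(=O)(=O)C1CC1` likewise stands only at a limit in this assay, < 75.2 ng.h/mL. Among the numbers shown, compound 3 therefore sits at a limit, with one further value also a limit and one entry without a number.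

The step of interest leads from compound 3 to compound 4 `C=C[C@@H]1C[C@]1(NC(=O)[C@@H]1C[C@@H]2CN1C(=O)[C@H](C1CCCCC1)N[C@H](C)CCCCCCc1cccc3c1CN(C3)C(=O)O2)C(=O)NS(=O)(=O)C1CC1`, which has not yet been measured in this assay. The two structures differ in one place: hydrogen in place of methyl on an amine nitrogen in a ring. For the measured compounds named here, no step between measured compounds is available to calibrate this change. Since compound 3 is known only through its limit < 75.2 ng.h/mL, the exposure of compound 4 in this assay is expected to change by a step that the limit leaves unreadable from compound 3 to compound 4, with no direction clearly beyond the scatter. Compound 4 is estimated to show 50 ng.h/mL, within a range from 10 ng.h/mL to 250 ng.h/mL.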

Compound 4, area under the concentration-time curve: < 73.8 ng.h/mL
Compound 4 ended at the assay's limit (the forecaster's own chance of this, stated with the estimate: 60%); the middle value lies beyond the limit too.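

Compound 3 and compound 4 are both known only through limits in this assay, and the step between them, hydrogen in place of methyl on the amine nitrogen, cannot be read. The compounds shown leave open whether this change alters oral exposure at all, and in which direction.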